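Thiazole in Place of Pyrrole on the Amide Side Chain

The source may hold more compounds than are shown below. What is called first, only, known or untested is meant among the compounds shown, and "the series" means these compounds.

Measured so far:
Compound 1, `CCN(Cc1ccoc1)C(=O)COc1ccc(C)cc1`: 136 nM
Compound 2, `CCN(Cc1cccnc1)C(=O)COc1ccc(C)cc1`: 15400 nM
Compound 3, `CCN(Cc1cc[nH]c1)C(=O)COc1ccc(C)cc1`: 21800 nM

All three share one core and differ only in the small aromatic ring carried on a saturated chain carbon bound to the amide-type nitrogen. In an assay on HEK293 cells for agonist activity at transient receptor potential cation channel subfamily M member 8 (Homo sapiens), read by fluorescence and calcium flux, with a stated time of 15 min (on this read-out lower numbers stand for an effect already at smaller amounts and higher numbers for an effect only at larger amounts of compound), compound 1 gives 136 nM. Compound 3 stands at the weak end of this set: a 160-fold higher number from compound 1 to compound 3 (2.20 log units; beyond the scatter), whereas its gap to compound 2 is small, a 1.4-fold higher number from compound 2 to compound 3 (0.15 log units; within the scatter).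

Compound 4, `CCN(Cc1nccs1)C(=O)COc1ccc(C)cc1`, is not yet measured. Its change from compound 3 is 1,3-thiazol-2-yl in place of 1H-pyrrol-3-yl on a saturated chain carbon bound to an amide-type nitrogen.

Within the data shown here, two measured steps bear on this. Replacing the furan of compound 1 by a pyridine gave a 110-fold higher number from compound 1 to compound 2 (2.05 log units; beyond the scatter), and replacing it by a pyrrole gave a 160-fold higher number from compound 1 to compound 3 (2.20 log units; beyond the scatter). The ring that enters in compound 4 shares with the furan of compound 1 the five-membered size and the lack of a donor, yet its attachment point and heteroatom count differ from every ring measured here, so the data support only a cautious guess. A moderate recovery toward compound 1 is expected rather than a full return.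

For compound 4 the estimate in this assay is 3000 nM, with a range from 300 nM to 30000 nM, which would be an expected 7.3-fold lower number from compound 3 to compound 4 (0.86 log units; beyond the scatter).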

Compound 4, half-maximal effective concentration: 3060 nM
Estimate against measurement, compound 4: 1.0-fold (0.01 log units) below; measured number inside the range.
By their numbers in this assay, from the lowest: compound 1; then compound 4; then compounds 2 and 3 (each within the scatter of the next).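

In this assay, the 1,3-thiazol-2-yl ring stands clear of the two weakest rings, with a 7.1-fold lower number from compound 3 to compound 4 (0.85 log units; beyond the scatter) and a 5.0-fold lower number from compound 2 to compound 4 (0.70 log units; beyond the scatter). At this place, on a saturated chain carbon bound to an amide-type nitrogen, swapping out furan-3-yl therefore does not always give the same poor result, although the recovery is only partial, with a 23-fold higher number from compound 1 to compound 4 (1.35 log units; beyond the scatter). The 1,3-thiazol-2-yl ring also brings in sulfur and has no hydrogen-bond donor, unlike the 1H-pyrrol-3-yl ring, but nothing measured here explains how any of these rings changes the number.

Several things change at once in this step, so the compounds shown leave open whether the gain goes with the sulfur, the second hetero atom or the point at which the ring is attached. A thiophen-3-yl group, with sulfur as its only hetero atom, and a 1,3-oxazol-2-yl group, with oxygen in place of the sulfur of compound 4, would help to pull these features apart.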